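Dropping the last methoxy group from compound 2

This account rests on a few compounds, and the source may have more. Where it says the series, first, only, none or still open, it means among the compounds named here.

Compound 2 `C=CCc1cc(-c2ccc(O)c(CC=C)c2)c(O)c(C(c2ccc(OC)cc2)N2CCCCC2)c1` stands highest of the two measured compounds in an assay on isolated protein for inhibition of Maltase-glucoamylase (Homo sapiens), with stated times of 15 min and 10 min, tested at 64 uM (a higher number here means more inhibition at the concentration tested (going by the name of the read-out), a lower number less inhibition), giving 85%. Its nearest neighbour, compound 1 `C=CCc1cc(-c2ccc(O)c(CC=C)c2)c(O)c(C(c2cc(OC)c(OC)c(OC)c2)N2CCCCC2)c1`, gives 56.4% in this assay. Among the compounds with values here, the only step measured so far, a number 28.6 percentage points higher from compound 1 to compound 2 (beyond the scatter), followed removal of two methoxy groups from the aryl ring. Compound 3 `C=CCc1cc(-c2ccc(O)c(CC=C)c2)c(O)c(C(c2ccccc2)N2CCCCC2)c1` now takes this further: hydrogen in place of methoxy on an aromatic carbon. By analogy with that earlier step, a small rise or no change beyond the scatter is expected, since the read-out cannot climb far. For compound 3 the estimate is 88%, ranging from 70% to 99%, a step of a number 3 percentage points higher from compound 2 to compound 3 (within the scatter).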

Compound 3, a percentage reported as inhibition, at one concentration (the size of the read-out at that concentration, not a potency): 13.6%
Beside the measured number, compound 3's estimate is 74.4 percentage points above it; the measured number lies below the stated range.
By their numbers in this assay, from the lowest: compound 3; then compound 1; then compound 2.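

In this assay the single methoxy of the 4-methoxyphenyl group proves decisive, with a large loss when hydrogen replaces it (a number 71.4 percentage points lower from compound 2 to compound 3 (beyond the scatter)). The phenyl also falls short of the 3,4,5-trimethoxyphenyl group (a number 42.8 percentage points lower from compound 1 to compound 3 (beyond the scatter)). Stripping methoxy groups from this ring therefore does not move the number in one direction across these compounds, and no evidence at hand explains the reversal.

Still open, from the compounds shown here alone, is whether methoxy itself is needed on this aromatic carbon, or whether a hydroxyl, a chlorine or an ethoxy group there would also hold the number up. These single-concentration percentages also leave the potency of the compounds undetermined.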